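The compounds below may be only part of what the source reports. "The series", "measured", "known", "first", "only" and "open" are said of these compounds alone.

Among the measured compounds shown here, in a functional assay on ECa-109 cells (Homo sapiens) for cytotoxicity, read by MTT assay, with a stated time of 72 h (a higher number here means a weaker inhibitor, a lower number a stronger inhibitor), compound 1 `O=C1C(=Cc2ccc(F)cc2)C(=O)N(c2ccc(Cl)cc2)N1c1ccc(Cl)cc1` gives 35600 nM and compound 2 `O=C1C(=Cc2ccc(F)cc2F)C(=O)N(c2ccc(Cl)cc2)N1c1ccc(Cl)cc1` gives 13100 nM as the lower of the only two numbers so far. For the measured compounds named here, the single measured step is a 2.7-fold lower number from compound 1 to compound 2 (0.43 log units; beyond the scatter) and it is modest, though beyond the scatter. The change to compound 3 `O=C1C(=Cc2c[nH]c3ccccc23)C(=O)N(c2ccc(Cl)cc2)N1c1ccc(Cl)cc1` is larger: 1H-indol-3-yl in place of 2,4-difluorophenyl on a double-bonded chain carbon bound to a double-bonded ring carbon with 1H-indol-3-yl in place of 2,4-difluorophenyl on a double-bonded chain carbon bound to a double-bonded ring carbon. One fluoro step gives no direction for swapping a whole ring, so the estimated move in this assay is a 1.1-fold higher number from compound 2 to compound 3 (0.03 log units; within the scatter) and nothing beyond the scatter is expected. Compound 3 is estimated at 14000 nM with a wide expected range (from 4000 nM to 50000 nM).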

Compound 3, half-maximal inhibitory concentration: 23400 nM
Compound 3: the middle estimate sits 1.7-fold (0.22 log units) below what was measured; measured number inside the range.
By their numbers in this assay, from the lowest: compounds 2, 3 and 1 (each within the scatter of the next, the first and the last beyond it).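

At this place, on a double-bonded chain carbon bound to a double-bonded ring carbon, a whole aromatic ring can be exchanged without a shift beyond the scatter. In this assay, 1H-indol-3-yl in place of 2,4-difluorophenyl gives a 1.8-fold higher number from compound 2 to compound 3 (0.25 log units; within the scatter) and 1H-indol-3-yl in place of 4-fluorophenyl gives a 1.5-fold lower number from compound 1 to compound 3 (0.18 log units; within the scatter) even though the two fluorinated compounds differ beyond the scatter. Nothing measured here explains these results. On these data alone, whether the hydrogen on the 1H-indol-3-yl nitrogen matters remains open. So does the effect of a ring carrying an amine or a carboxylic acid at this place.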